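A Smaller Halogen Pattern on the Phenoxy Arm

This account rests on a few compounds, and the source may have more. Where it says the series, first, only, none or still open, it means among the compounds named here.

Compound 1 `Nc1cc(N)c2nc(-c3ccccc3)c(Oc3ccc(Cl)c(Cl)c3)nc2c1` was tested in a functional assay on SR cells (Homo sapiens) for inhibition, read by sulforhodamine B assay, with a stated time of 48 h; on this read-out higher numbers stand for lower toxicity in this test and lower numbers for higher toxicity in this test. For compound 1 the result is only a limit, < 100000 nM, and not a measured number. Two companions share its core. Compound 2 `CCOC(=O)[C@H](CCC(=O)O)NC(=O)c1ccc(CNc2nc3cc(N)cc(N)c3nc2-c2ccccc2)cc1` carries a longer side chain and gives 93300 nM in this assay. Compound 3 `COc1ccc(CNc2nc3cc(N)cc(N)c3nc2-c2ccccc2)cc1` reaches only a limit in this assay, namely < 100000 nM. On the numbers shown, compound 1 stands at the limit of < 100000 nM in this assay, at which 2 of the 3 values shown sit. Among the measured compounds shown here, no two measured compounds differ in a single place, so no measured step is available to lean on.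

Compound 4 `Nc1cc(N)c2nc(-c3ccccc3)c(Oc3ccc(F)cc3)nc2c1` departs from compound 1 in one way: 4-fluorophenyl in place of 3,4-dichlorophenyl on an oxygen on an aromatic ring. Without a comparable measured step, the expectation is that this change produces no difference beyond the usual scatter, so the step that the limit leaves unreadable from compound 1 to compound 4 is expected to be small and without a clear direction. Compound 4 is therefore estimated at 70000 nM, with a plausible range from 20000 nM to 100000 nM, and it may well again return only a limit rather than a number.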

Compound 4, concentration lethal to 50% of the cells: < 100000 nM
Compound 4 was reported as a limit; the forecaster's own chance of this, stated with the estimate: 55%; the middle value does not contradict the limit.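

In this assay compound 4 gives < 100000 nM, which is again a limit and not a number. Compound 1 also returned only a limit, so no step can be read between compound 1 and compound 4. Compound 4 joins most of the set shown: the limit of < 100000 nM in this assay, at which 3 of the 4 values shown sit. Open, on these data alone, is whether replacing 3,4-dichlorophenyl with 4-fluorophenyl changes this read-out at all.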